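The source may hold more compounds than are shown below. What is called first, only, known or untested is meant among the compounds shown, and "the series" means these compounds.

Measured so far in a functional assay on LNCaP cells (Homo sapiens) for cytotoxicity, read by MTT assay; on this read-out lower numbers stand for stronger inhibition and higher numbers for weaker inhibition:
- compound 1 `COc1ccc2cc([C@H](C)c3nnc(SCc4ccc(Cl)cc4)n3-c3ccc(F)cc3)ccc2c1`: > 400000 nM (a limit of the assay)
- compound 2 `COc1ccc(CSc2nnc([C@@H](C)c3ccc4cc(OC)ccc4c3)n2-c2ccc(F)cc2)cc1`: 22800 nM
- compound 3 `COc1ccc2cc([C@H](C)c3nnc(SCc4c(Cl)cccc4Cl)n3-c3ccc(F)cc3)ccc2c1`: 12300 nM

Compound 3 stands level with compound 2, since a 1.9-fold lower number from compound 2 to compound 3 (0.27 log units; within the scatter). Compound 1 gives no number to compare, only a limit of > 400000 nM.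

Compound 4 `COc1ccc2cc([C@H](C)c3nnc(SCc4c(C)cc(C)cc4C)n3-c3ccc(F)cc3)ccc2c1` keeps the core of compound 3 and changes one group: 2,4,6-trimethylphenyl in place of 2,6-dichlorophenyl on a saturated chain carbon bound to a sulfur. In words, 2,4,6-trimethylphenyl stands in place of 2,6-dichlorophenyl on a saturated chain carbon bound to a sulfur.

For the measured compounds named here, the steps that bear on this change all sit at that same place. Two are large: an at least 17-fold lower number from compound 1 to compound 2 (1.24 log units; beyond the scatter), and an at least 32-fold lower number from compound 1 to compound 3 (1.51 log units; beyond the scatter). As far as these compounds go, both start from the limit of compound 1, so their true sizes are unknown. The third is a 1.9-fold lower number from compound 2 to compound 3 (0.27 log units; within the scatter), which shows that exchanging 4-methoxyphenyl for 2,6-dichlorophenyl made no clear difference. Compound 1 is therefore the only one of the three that goes against a level result at this place. Going by the values given here, no measured compound carries the methyl groups of compound 4, so the expectation is loose.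

In this assay, the expected change is no step beyond the scatter: a 1.2-fold higher number from compound 3 to compound 4 (0.09 log units; within the scatter). The estimate for compound 4 is 15000 nM, with an expected range from 5000 nM to 60000 nM.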

Compound 4, half-maximal inhibitory concentration: 2210 nM
The estimate for compound 4 lay 6.8-fold (0.83 log units) above the measured number; the measured number lies below the stated range.
By their numbers in this assay, from the lowest: compound 4; then compounds 3 and 2 (each within the scatter of the next). At a limit, above all of these: compound 1.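

For the compounds shown here, until now, the only real numbers at this place, the saturated chain carbon bound to a sulfur, formed a level pair; compound 4 shows that the result in this assay can move beyond the scatter here, with a 5.6-fold lower number from compound 3 to compound 4 (0.75 log units; beyond the scatter). The same holds against the other compound with a real number, with a 10-fold lower number from compound 2 to compound 4 (1.01 log units; beyond the scatter), so 2,4,6-trimethylphenyl gives the lowest number of the four, and each of its steps to the others is printed as beyond the scatter. The step to compound 1 can be read only as a minimum, an at least 180-fold lower number from compound 1 to compound 4 (2.25 log units; beyond the scatter), since compound 1 gives a limit and not a number: the limit of > 400000 nM in this assay, at which 1 of the 4 values shown sits.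

The compounds shown do not separate the three methyl groups of 2,4,6-trimethylphenyl, so it stays open whether all of them are needed for the lower number, and a single exchange of the whole ring cannot say why the number fell. As far as these compounds go, it also stays open how the result in this assay would read with an amine or a carboxylic acid on this ring.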